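This account rests on a few compounds, and the source may have more. Where it says the series, first, only, none or still open, it means among the compounds named here.

Series notes. The parent acid, compound 1 `O=C(O)CCC(=O)OCCCCCCSc1ccc([N+](=O)[O-])c2nonc12`, carries a free carboxylic acid at the end of the chain; in an assay on isolated protein for inhibition of glutathione S-transferase P (Homo sapiens), with a stated time of 10 min (a lower number here means a stronger inhibitor, a higher number a weaker inhibitor), compound 1 gives 530 nM. Its anilide, compound 2 `O=C(CCC(=O)OCCCCCCSc1ccc([N+](=O)[O-])c2nonc12)Nc1ccc(Br)cc1`, is the weaker of the two measured compounds: in this assay compound 2 gives 5090 nM, and the step of a 9.6-fold higher number from compound 1 to compound 2 (0.98 log units; beyond the scatter) shows that capping the acid as the (4-bromophenyl)amide cost potency.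

The next compound, compound 3 `COc1ccc(NC(=O)CCC(=O)OCCCCCCSc2ccc([N+](=O)[O-])c3nonc23)cc1OC`, keeps the amide but swaps the aryl group: 3,4-dimethoxyphenyl in place of 4-bromophenyl on an amide-type nitrogen. Among the compounds with values here, no measured step concerns a change of the aryl substituent on this amide nitrogen; the only step in hand, a 9.6-fold higher number from compound 1 to compound 2 (0.98 log units; beyond the scatter), concerns acid versus anilide and so says nothing direct about one anilide against another. With the amide already in place, the exchange of one aryl group for another is expected to move this assay little, and a step of about a 1.0-fold lower number from compound 2 to compound 3 (0.01 log units; within the scatter), that is no change beyond the scatter, is the working expectation. Compound 3 is therefore estimated at 5000 nM, with a range of 1800 nM to 14000 nM.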

Compound 3, half-maximal inhibitory concentration: 6470 nM
The estimate for compound 3 lay 1.3-fold (0.11 log units) below the measured number; the measured number falls inside the stated range.
By their numbers in this assay, from the lowest: compound 1; then compounds 2 and 3 (each within the scatter of the next).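

The exchange of 4-bromophenyl for 3,4-dimethoxyphenyl on the amide-type nitrogen gives a 1.3-fold higher number from compound 2 to compound 3 (0.10 log units; within the scatter) in this assay, so this assay does not separate these two aryl groups, even though they differ in heavy atoms and in counted hydrogen-bond acceptors. The second anilide gives a 12-fold higher number from compound 1 to compound 3 (1.09 log units; beyond the scatter), which shows that the loss on replacing hydroxy at the carbonyl carbon is not confined to the 4-bromophenyl amide: it recurs with a second aryl group, and compound 1 remains the strongest of the three. No measured evidence bears on the origin of either result.

The compounds shown cannot separate the contribution of the amide linkage from that of the aryl ring, a question that a methylamino group or a simple methyl ester on the same carbonyl carbon would address. They also leave open whether a carboxylic acid or an amine carried on the aryl ring would recover the number of compound 1, 530 nM, within the anilide series.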